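A few compounds are considered here, and "the series" means these few. Any claim that something is new, unique, unknown or untested is made for them only; others in the source may bear on it.

Compound 1 `CCCOC1=CC(=O)c2ccccc2C1=O`: 51600 nM
Compound 2 `Cc1ccc(S(=O)(=O)Oc2cccc3c2C(=O)C=CC3=O)cc1`: 9470 nM

Both values come from a functional assay on HeLa cells (Homo sapiens) for cytotoxicity; on this read-out higher numbers stand for weaker inhibition and lower numbers for stronger inhibition. Compound 1 has the higher number of the two, and the gap to compound 2 lies beyond the scatter. Compound 3 `CS(=O)(=O)OC1=CC(=O)c2ccccc2C1=O` is the next compound, with this change from compound 1: methylsulfonyl in place of propyl on an oxygen on an unsaturated carbon. In words, methylsulfonyl takes the place of propyl on an oxygen on an unsaturated carbon. For the measured compounds named here, no measured step covers this change, so the basis is thin. Compound 2, also with a sulfonyl group on oxygen, gives 9470 nM, so a step to a lower number, beyond the scatter, is expected. The expected step is a 4.3-fold lower number from compound 1 to compound 3 (0.63 log units; beyond the scatter). Compound 3 is estimated at 12000 nM, with a range of 3000 nM to 45000 nM.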

Compound 3, half-maximal inhibitory concentration: 7610 nM
Beside the measured number, compound 3's estimate is 1.6-fold (0.20 log units) above it; measured number inside the range.
By their numbers in this assay, from the lowest: compounds 3 and 2 (each within the scatter of the next); then compound 1.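

In this assay, for the compounds shown here, the change from propoxy to (methylsulfonyl)oxy gives a 6.8-fold lower number from compound 1 to compound 3 (0.83 log units; beyond the scatter) as the first measured step at this position. The read-out on the shared core therefore responds to what sits on this oxygen, though this rests on a single pair. Nothing measured bears on the reason for the step. Still open, from the compounds shown here alone, is whether the step holds for a longer chain on the sulfonyl group, such as butylsulfonyl, and how an acetyl group on the same oxygen would compare.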